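Chloro for methyl on the compound 1 scaffold

This account rests on a few compounds, and the source may have more. Where it says the series, first, only, none or still open, it means among the compounds named here.

In a functional assay on HL-60 cells (Homo sapiens) for inhibition (a higher number here means a weaker inhibitor of growth, a lower number a stronger inhibitor of growth), compound 1 (`C=C(C)C(=O)c1ccc(OCc2nc(C)no2)cc1C`) gives 3820 nM and compound 2 (`C=C(C)C(=O)c1ccc(OCc2nc(-c3ccc(F)cc3)no2)cc1C`) gives 4600 nM while compound 3 (`C=C(C)C(=O)c1ccc(OCc2nc(-c3ccc([N+](=O)[O-])cc3)no2)cc1C`) gives 6100 nM under the same read-out. Compound 1 therefore stands level with the other two, as all three lie within the scatter of one another.

Compound 4 (`C=C(C)C(=O)c1ccc(OCc2nc(C)no2)cc1Cl`) is still unmeasured. Its change from compound 1 is chloro in place of methyl on an aromatic carbon, ortho to a (1-methylethenyl)carbonyl group and meta to a group of 8 heavy atoms.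

The evidence on this change is only indirect. At a different place in the molecule the steps were a 1.2-fold higher number from compound 1 to compound 2 (0.08 log units; within the scatter) and a 1.6-fold higher number from compound 1 to compound 3 (0.20 log units; within the scatter) with a 1.3-fold higher number from compound 2 to compound 3 (0.12 log units; within the scatter) at that same place, and all of them stay within the scatter. For the measured compounds named here, none of them touches the methyl that compound 4 gives up, and no measured pair compares chloro with methyl at this position.

No step beyond the scatter is expected, in either direction. The estimated 1.1-fold lower number from compound 1 to compound 4 (0.04 log units; within the scatter) carries no firm direction. For compound 4 the expected value is 3500 nM with an estimated range from 1500 nM to 8000 nM as the likely span.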

Compound 4, concentration for 50% growth inhibition: 9700 nM
Estimate against measurement, compound 4: 2.8-fold (0.44 log units) below; the whole stated range lies below it.
By their numbers in this assay, from the lowest: compounds 1, 2, 3 and 4 (each within the scatter of the next, the first and the last beyond it).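

In this assay, the aromatic carbon ortho to a (1-methylethenyl)carbonyl group is the only place among the compounds shown where a single change gives a step beyond the scatter: chloro in place of methyl gives a 2.5-fold higher number from compound 1 to compound 4 (0.40 log units; beyond the scatter). The earlier steps shown here all lay at a different place in the molecule and stayed within the scatter, so this position is more sensitive to change in this read-out than those steps could indicate, although the step is modest and rests on a single pair. Nothing available explains why chloro gives the higher number here.

Open, on these data alone, is whether the methyl itself is what matters on this carbon, or whether other groups there, such as methoxy, bromo, an amine or a longer chain, would stay level with compound 1 or move further in the direction of compound 4. Also open, as far as these compounds go, is whether chloro in place of methyl gives a step of the same size on the compound 2 and compound 3 scaffolds, which carry 4-fluorophenyl and 4-nitrophenyl in place of the methyl at the other site.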